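A few compounds are considered here, and "the series" means these few. Any claim that something is new, unique, unknown or untested is made for them only; others in the source may bear on it.

Three compounds share one core and differ only in the group on an aromatic carbon of the fused ring. Compound 1 `COc1cc(-c2ccnc3cc(-c4ccc(C(C)(C)C)cc4)nn23)cc(OC)c1OC` carries 4-(tert-butyl)phenyl, compound 2 `COc1cc(-c2ccnc3cc(-c4ccc5ccn(C)c5c4)nn23)cc(OC)c1OC` 1-methyl-1H-indol-6-yl, and compound 3 `COc1cc(-c2ccnc3cc(-c4ccc5c(ccn5C)c4)nn23)cc(OC)c1OC` 1-methyl-1H-indol-5-yl. In a functional assay on HCT-116 cells (Homo sapiens) for inhibition, read by CCK-8 assay, with a stated time of 48 h (on this read-out lower numbers stand for stronger inhibition and higher numbers for weaker inhibition), compound 1 reaches only a limit, > 10000 nM. Compound 2 gives 1040 nM, while compound 3 gives 39 nM, the lowest number measured, with a 27-fold lower number from compound 2 to compound 3 (1.43 log units; beyond the scatter) and an at least 250-fold lower number from compound 1 to compound 3 (2.40 log units; beyond the scatter). Compound 4 `COc1cc(-c2ccnc3cc(-c4ccc(F)cc4)nn23)cc(OC)c1OC` differs from compound 3 by 4-fluorophenyl in place of 1-methyl-1H-indol-5-yl on an aromatic carbon. The step bearing on this is an at least 250-fold lower number from compound 1 to compound 3 (2.40 log units; beyond the scatter), which compound 4 largely reverses by returning to a substituted phenyl, so a large rise in this assay is expected, a 77-fold higher number from compound 3 to compound 4 (1.89 log units; beyond the scatter). Compound 4 is therefore estimated at 3000 nM, within 500 nM to 20000 nM.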

Compound 4, half-maximal inhibitory concentration: 5030 nM
Compound 4: middle estimate off by 1.7-fold (0.22 log units), on the low side, and the stated range covers the measured number.
By their numbers in this assay, from the lowest: compound 3; then compound 2; then compound 4. At a limit, above all of these: compound 1.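

With 4-fluorophenyl at this position there is a 130-fold higher number from compound 3 to compound 4 (2.11 log units; beyond the scatter), and there is an at least 1.9-fold lower number from compound 1 to compound 4 (0.29 log units; that floor lies within the scatter), so the loss seen with 4-(tert-butyl)phenyl is not confined to that one phenyl group, and among the groups shown the lowest number belongs to 1-methyl-1H-indol-5-yl. Even the weaker indole outperforms this phenyl, with a 4.8-fold higher number from compound 2 to compound 4 (0.68 log units; beyond the scatter). Compound 1 stands only at a limit, so its step to compound 4 gives no more than a floor: the limit of > 10000 nM in this assay, at which 1 of the 4 values shown sits.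

Which part of 1-methyl-1H-indol-5-yl accounts for the low number remains open. A phenyl bearing an amine or a methoxy group could fall on either side of these values.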